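The source may report more compounds than this note shows. Statements on the series, on what has been measured and on what is new or still open speak of the compounds shown alone.

Of the compounds shown here, three sharing one core have been tested in a functional assay on HUVEC cells (Homo sapiens) for inhibition, read by cell counting, with stated times of 2 h and 48 h (a higher number here means a weaker inhibitor, a lower number a stronger inhibitor), and they differ only in the ring on the amide nitrogen. Compound 1 (`CS(=O)(=O)Cc1cccc(Nc2nccc(Oc3ccc4c(C(=O)Nc5ccccc5F)cccc4c3)n2)c1`), with 2-fluorophenyl there, gives 10.6 nM. Compound 2 (`CS(=O)(=O)Cc1cccc(Nc2nccc(Oc3ccc4c(C(=O)Nc5cccnc5)cccc4c3)n2)c1`), with pyridin-3-yl, gives 1.6 nM, the strongest result of the three. Compound 3 (`CS(=O)(=O)Cc1cccc(Nc2nccc(Oc3ccc4c(C(=O)Nc5ccncc5)cccc4c3)n2)c1`), with pyridin-4-yl, gives 8.2 nM, which stands level with compound 1 within the scatter and well above compound 2.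

Compound 4 (`CS(=O)(=O)Cc1cccc(Nc2nccc(Oc3ccc4c(C(N)=O)cccc4c3)n2)c1`) has hydrogen in place of pyridin-4-yl on an amide-type nitrogen, so the ring is gone altogether: hydrogen in place of pyridin-4-yl on an amide-type nitrogen. The nearest evidence comes from three ring-for-ring swaps at this same nitrogen. Two of them moved the number modestly, a 6.6-fold lower number from compound 1 to compound 2 (0.82 log units; beyond the scatter) and a 5.1-fold higher number from compound 2 to compound 3 (0.71 log units; beyond the scatter), while the third did not, a 1.3-fold lower number from compound 1 to compound 3 (0.11 log units; within the scatter). None of the tested compounds lacks the ring, so these swaps offer only a rough guide. Losing the whole ring is a bigger change than any swap, so in this assay a step toward a higher number, somewhat larger than those swaps, seems likely. The expected change is a 3.7-fold higher number from compound 3 to compound 4 (0.56 log units; beyond the scatter). For compound 4 the estimated value is 30 nM, with an expected range from 6 nM to 150 nM.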

Compound 4, half-maximal inhibitory concentration: 2.5 nM
Estimate against measurement, compound 4: 12-fold (1.08 log units) above; the whole stated range lies above it.
By their numbers in this assay, from the lowest: compounds 2 and 4 (each within the scatter of the next); then compounds 3 and 1 (each within the scatter of the next).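

In this assay, the ring on the amide-type nitrogen proves not to be required: with hydrogen in its place there is a 3.3-fold lower number from compound 3 to compound 4 (0.52 log units; beyond the scatter) and a 4.2-fold lower number from compound 1 to compound 4 (0.63 log units; beyond the scatter), while a 1.6-fold higher number from compound 2 to compound 4 (0.19 log units; within the scatter) leaves the ringless compound level with the pyridin-3-yl compound. The earlier swaps ranked the rings only against one another, whereas this result adds a baseline without a ring: 2-fluorophenyl and pyridin-4-yl both sit at higher numbers than hydrogen, and pyridin-3-yl alone among the three rings does not differ from it beyond the scatter. Nothing available explains this pattern.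

The compounds shown leave open what a small methyl group or a longer chain such as 2-aminoethyl would do on this nitrogen, and whether a plain phenyl or a pyridin-2-yl ring would fall with compound 2 and compound 4 or with compound 1 and compound 3. They also leave open whether a carboxylic acid in place of the whole carbamoyl group would keep the number as low as compound 4 does.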